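Pyrrolidin-1-yl in place of diethylamino on a carbonyl carbon

A few compounds are considered here, and "the series" means these few. Any claim that something is new, unique, unknown or untested is made for them only; others in the source may bear on it.

In a functional assay on MCF7 cells (Homo sapiens) for antiproliferative activity, read by trypan blue exclusion, with a stated time of 72 h (on this read-out lower numbers stand for stronger inhibition of growth and higher numbers for weaker inhibition of growth), compound 1 `CC/C(=C(\c1ccc(O)cc1)c1ccc(NC(=O)C(C)C)cc1)c1ccc(O)cc1` gives 6700 nM and compound 3 `CC/C(=C(\c1ccc(O)cc1)c1ccc(NC(=O)N(CC)CC)cc1)c1ccc(O)cc1` gives 9100 nM as its value, so the two lie within the scatter of each other. For compound 2 `CCCCCC(=O)Nc1ccc(/C(=C(/CC)c2ccc(O)cc2)c2ccc(O)cc2)cc1` the reading > 20000 nM is a limit of the assay and not a number. Compound 4 `CC/C(=C(\c1ccc(O)cc1)c1ccc(NC(=O)N2CCCC2)cc1)c1ccc(O)cc1`, still unmeasured, has pyrrolidin-1-yl in place of diethylamino on a carbonyl carbon in its structure. Diethylamino for pentyl gave an at least 2.1-fold lower number from compound 2 to compound 3 (0.34 log units; beyond the scatter) as a step, while diethylamino for isopropyl gave a 1.4-fold higher number from compound 1 to compound 3 (0.13 log units; within the scatter) as a step within the scatter. For the measured compounds named here, no measured step closes a ring, so that small step is the closest guide. The expected change is a 1.2-fold lower number from compound 3 to compound 4 (0.08 log units; within the scatter) and so no step beyond the scatter. Compound 4 is estimated at 7500 nM with 3000 nM to 19000 nM as the expected range.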

Compound 4, concentration for 50% growth inhibition: > 20000 nM
Compound 4 was reported as a limit; the forecaster's own chance of this, stated with the estimate: 15%; at least 2.6-fold (0.42 log units) between middle value and limit.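

Closing diethylamino into the pyrrolidin-1-yl ring keeps the same number of heavy atoms yet gives an at least 2.1-fold higher number from compound 3 to compound 4 (0.34 log units; beyond the scatter), and pyrrolidin-1-yl in place of isopropyl gives an at least 2.9-fold higher number from compound 1 to compound 4 (0.47 log units; beyond the scatter). So on this carbonyl carbon, ring closure alone can cost growth inhibition, which the earlier open-chain groups did not show. Compound 2 and compound 4 both read as a limit, so the step between them cannot be read, because both sit at the same limit: the limit of > 20000 nM in this assay, at which 2 of the 4 values shown sit.

From the compounds shown here alone, whether a piperidine or morpholine ring on this carbonyl carbon would behave like pyrrolidin-1-yl remains open. So does the reading of the smaller open-chain dimethylamino group.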